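A Larger Hydroxylated Ring on the Shared Core

The source may report more compounds than this note shows. Statements on the series, on what has been measured and on what is new or still open speak of the compounds shown alone.

Compound 1 `N#Cc1cnc(NCc2cnccc2C(F)(F)F)cc1N[C@H]1C[C@H](O)C1` was tested in an assay on isolated protein for inhibition of protein kinase C delta type (Homo sapiens), read by TR-FRET, with a stated time of 2 h; on this read-out higher numbers stand for weaker inhibition and lower numbers for stronger inhibition. There compound 1 returns only a limit, > 10000 nM. Compound 2 `N#Cc1cnc(NCc2ccccc2)cc1N[C@H]1CC[C@@H](O)CC1` likewise returns only a limit in this assay, > 10000 nM. Going by the values given here, both sit at the limit of > 10000 nM in this assay, at which 2 of the 2 values shown sit, so compound 1 stands level with the only other compound measured. Compound 3 `CC1(C)C[C@H](Nc2cc(NCc3cnccc3C(F)(F)F)ncc2C#N)CC[C@@H]1O` differs from compound 1 in one place: 4-hydroxy-3,3-dimethylcyclohexyl in place of 3-hydroxycyclobutyl on a nitrogen on an aromatic ring. Among the compounds with values here, no measured step between compounds is available, and no shift beyond the scatter is expected in either direction in this assay. Compound 3 is therefore estimated at 10000 nM, within 3000 nM to 30000 nM. The expected step is a number no higher from compound 1 to compound 3 (the limit leaves the size open).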

Compound 3, half-maximal inhibitory concentration: 500 nM
The estimate for compound 3 lay 20-fold (1.30 log units) above the measured number, outside the stated range (below it).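

Replacing 3-hydroxycyclobutyl with 4-hydroxy-3,3-dimethylcyclohexyl on this nitrogen changes the result in this assay: the change gives an at least 20-fold lower number from compound 1 to compound 3 (1.30 log units; beyond the scatter). Going by these compounds alone, this place on the shared core therefore responds to the group it carries, which the earlier compounds could not show. Compound 3 is the only compound shown that comes off the limit of the assay: the limit of > 10000 nM in this assay, at which 2 of the 3 values shown sit.

The one change enlarges the ring and adds the dimethyl substitution together, and the compounds shown do not separate the two. They also leave open what the hydroxyl contributes, which an amine or a methoxy group in its place would test.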